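Bromo at the methoxy-bearing ring of the benzyl arm

The compounds below may be only part of what the source reports. "The series", "measured", "known", "first", "only" and "open" are said of these compounds alone.

The series shares one core; compound 3 `COc1ccc(CN(C(=O)CSc2nc3ccccc3s2)c2cc(OC)c(OC)c(OC)c2)cc1` carries the 4-methoxybenzyl arm unsubstituted. In a functional assay on HCT-116 cells (Homo sapiens) for antiproliferative activity, read by MTT assay, with a stated time of 48 h (a higher number here means a weaker inhibitor, a lower number a stronger inhibitor), compound 3 gives 426 nM, the lowest number among the values shown. Compound 2 `COc1ccc(CN(C(=O)CSc2nc3ccccc3s2)c2cc(OC)c(OC)c(OC)c2)cc1[N+](=O)[O-]` in this assay gives 1280 nM, and the step of a 3.0-fold lower number from compound 2 to compound 3 (0.48 log units; beyond the scatter) is modest. Compound 1 `COc1ccc(CN(C(=O)CSc2nc3ccccc3s2)c2cc(OC)c(OC)c(OC)c2)cc1C(F)(F)F` sits at a limit of this assay, (the limit of > 80000 nM in this assay, at which 1 of the 3 values shown sits), so compound 1 in this assay gives > 80000 nM as a limit and not a number. The step of an at least 180-fold lower number from compound 1 to compound 3 (2.27 log units; beyond the scatter) is large, and an at least 62-fold lower number from compound 1 to compound 2 (1.79 log units; beyond the scatter) likewise.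

Compound 4 `COc1ccc(CN(C(=O)CSc2nc3ccccc3s2)c2cc(OC)c(OC)c(OC)c2)cc1Br` differs from compound 3 by bromo in place of hydrogen on an aromatic carbon. Both steps that bear on this position point the same way: a substituent in place of hydrogen there gave a higher number, modest for nitro and large for trifluoromethyl. Bromo is expected to raise the number too, and the step of a 3.5-fold higher number from compound 3 to compound 4 (0.55 log units; beyond the scatter) is estimated as modest, nearer the nitro case. For compound 4 in this assay the expected value is 1500 nM, with a range from 450 nM to 8000 nM.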

Compound 4, half-maximal inhibitory concentration: 4550 nM
Compound 4: the middle estimate sits 3.0-fold (0.48 log units) below what was measured; the measured number falls inside the stated range.
By their numbers in this assay, from the lowest: compound 3; then compound 2; then compound 4. At a limit, above all of these: compound 1.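

On the 3-bromo-4-methoxybenzyl arm, one bromine atom ortho to a methoxy group is enough for a large loss in this assay: an 11-fold higher number from compound 3 to compound 4 (1.03 log units; beyond the scatter). Bromo also separates from nitro at this position, with a 3.6-fold higher number from compound 2 to compound 4 (0.55 log units; beyond the scatter), so a substituent in place of hydrogen here has now raised the number in all three cases, by clearly different amounts. The step of an at least 17-fold lower number from compound 1 to compound 4 (1.24 log units; beyond the scatter) gives only a bound on the gap to trifluoromethyl, and the figure for compound 1 is a limit and not a number: the limit of > 80000 nM in this assay, at which 1 of the 4 values shown sits.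

As far as these compounds go, what orders hydrogen, nitro, bromo and trifluoromethyl at this position stays open. From the compounds shown here alone, it is also open whether fluoro, chloro, an amine or a carboxylic acid there would stay close to compound 3 or follow compound 4.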